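This account rests on a few compounds, and the source may have more. Where it says the series, first, only, none or still open, it means among the compounds named here.

Working notes on the series. Compound 1 `COc1ccc(CNc2nc3cc(N)cc(N)c3nc2-c2ccccc2)cc1OC` gives 81300 nM in a functional assay on ACHN cells (Homo sapiens) for inhibition, read by sulforhodamine B assay, with a stated time of 48 h; a lower number here means that less compound is tolerated, a higher number that more compound is tolerated. Compound 2 `CCOC(=O)[C@H](CCC(=O)O)NC(=O)c1ccc(Sc2nc3cc(N)cc(N)c3nc2-c2ccccc2)cc1` reaches only a limit in this assay, < 100000 nM, which is a bound of the assay rather than a number (the limit of < 100000 nM in this assay, at which 1 of the 3 values shown sits). Among the measured compounds shown here, compound 3 `Nc1cc(N)c2nc(-c3ccccc3)c(Sc3ccc(Cl)c(Cl)c3)nc2c1` gives 5620 nM in this assay, the lowest of the two numbers so far; the gap to compound 1 lies beyond the usual scatter.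

Compound 4 `Nc1cc(N)c2nc(-c3ccccc3)c(Sc3ccc(F)cc3)nc2c1` differs from compound 3 in one place: 4-fluorophenyl in place of 3,4-dichlorophenyl on a sulfur. For the measured compounds named here, no step between measured compounds bears on this exchange. The expected step from compound 3 to compound 4 in this assay is a 2.7-fold higher number from compound 3 to compound 4 (0.43 log units; beyond the scatter), a moderate rise in the number. Compound 4 is estimated at 15000 nM in this assay, within a range of 4000 nM to 60000 nM.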

Compound 4, concentration lethal to 50% of the cells: < 100000 nM
Compound 4 gave a limit, no number; the forecaster's own chance of this, stated with the estimate: 10%; the middle value does not contradict the limit.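

In this assay, among the compounds shown here, compound 4 reaches only a limit of < 100000 nM and not a number, so no step from compound 3 to compound 4 can be read. The compounds shown leave open how far, and in which direction, 4-fluorophenyl in place of 3,4-dichlorophenyl on a sulfur moves the number.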